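The source may hold more compounds than are shown below. What is called first, only, known or untested is meant among the compounds shown, and "the series" means these compounds.

In an in vitro ADME assay on microsomes from liver (Homo sapiens) for metabolic stability (a lower number here means that the compound disappears faster, a higher number that the compound lasts longer), compound 1 `CS(=O)(=O)Nc1ccc2c(c1)S(=O)(=O)N=C(C1=C(O)C3CCCC3N(Cc3ccccn3)C1=O)N2` reaches the limit of the measurement, > 1 h, which is a limit and not a number. Compound 2 `CS(=O)(=O)Nc1ccc2c(c1)S(=O)(=O)N=C(C1=C(O)C3CCCC3N(Cc3ccc(F)cn3)C1=O)N2` likewise gives a limit, > 1 h. Compound 3 `CS(=O)(=O)Nc1ccc2c(c1)S(=O)(=O)N=C(C1=C(O)[C@H]3CCC[C@H]3N(Cc3ccc(F)c(F)c3)C1=O)N2` also stands at a limit, > 1 h. Going by the values given here, the only step between measured compounds, a step that the two limits leave unreadable from compound 1 to compound 2, has no readable size, since both its ends are limits. The whole of the evidence therefore reads: the limit of > 1 h in this assay, at which 3 of the 3 values shown sit. Compound 3 thus sits where every measured compound sits, at the limit, and nothing within the measured set separates it from the others.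

Compound 4 `Cc1cc(CN2C(=O)C(C3=NS(=O)(=O)c4cc(NS(C)(=O)=O)ccc4N3)=C(O)[C@H]3CCC[C@H]32)ccc1F` differs from compound 3 in one place: methyl in place of fluoro on an aromatic carbon. Among the compounds with values here, no measured step swaps a fluoro for a methyl on a benzene ring, so no measured step bears directly on this change, and the one step that exists is itself unreadable. Compound 4 is therefore expected to behave like compound 3 and most likely to return a limit again; the estimated step that the limit leaves unreadable from compound 3 to compound 4 is expected to stay within the usual scatter. Compound 4 is estimated at 1.5 h, with a range from 0.6 h to 4 h.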

Compound 4, half-life: > 1 h
Compound 4 was reported as a limit (the forecaster's own chance of this, stated with the estimate: 65%); the middle value lies beyond the limit too.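

Going by these compounds alone, compound 3 and compound 4 both stand at a limit of the measurement in this assay, so the change from fluoro to methyl gives no step whose size can be read. The compounds shown leave open how long each one actually lasts and whether they differ at all, since all that is seen is this: the limit of > 1 h in this assay, at which 4 of the 4 values shown sit.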